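Replacing benzyl with (3-nitrophenyl)carbonyl on compound 2

A few compounds are considered here, and "the series" means these few. Any claim that something is new, unique, unknown or untested is made for them only; others in the source may bear on it.

Measured so far in a functional assay on MCF7 cells (Homo sapiens) for antiproliferative activity, read by MTT assay, with a stated time of 72 h; a lower number here means a stronger inhibitor, a higher number a weaker inhibitor:
Compound 1 `CC(=O)O[C@H]1CC[C@]2(C)[C@H](CC[C@@](C)(O)[C@H]2CC[C@@H]2C(C)=CC[C@H]3[C@H](CC[C@]3(C)OC(C)=O)C2(C)C)OC1(C)C` gives 39200 nM
Compound 2 `CC1=CC[C@H]2[C@H](CC[C@]2(C)O)C(C)(C)[C@@H]1CC[C@H]1[C@]2(C)CC[C@H](OCc3ccccc3)C(C)(C)O[C@H]2CC[C@@]1(C)O` gives > 50000 nM (a limit, not a number)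
Compound 3 `CC1=CC[C@H]2[C@H](CC[C@]2(C)O)C(C)(C)[C@@H]1CC[C@H]1[C@]2(C)CC/C(=N/OC(=O)c3ccccc3)C(C)(C)O[C@H]2CC[C@@]1(C)O` gives 25600 nM

Compound 2 stands at the limit of > 50000 nM in this assay, at which 1 of the 3 values shown sits, and that reading is a limit, not a number. Compound 1 and compound 3 both give numbers, and those two values lie within the usual scatter of each other.

The next compound to be tested is compound 4 `CC1=CC[C@H]2[C@H](CC[C@]2(C)O)C(C)(C)[C@@H]1CC[C@H]1[C@]2(C)CC[C@H](OC(=O)c3cccc([N+](=O)[O-])c3)C(C)(C)O[C@H]2CC[C@@]1(C)O` and it differs from compound 2 in one place. On an oxygen on a saturated carbon, (3-nitrophenyl)carbonyl stands in place of benzyl: (3-nitrophenyl)carbonyl in place of benzyl on an oxygen on a saturated carbon and the rest of the structure is unchanged.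

Within the data shown here, no measured pair shows this change, so any expectation here is loose. Compound 3 also has a carbonyl joined to an aromatic ring and gives 25600 nM as a number, which points to a modest move toward stronger inhibition. Compound 4 could still stay at the limit. The expected change is small, an at least 1.7-fold lower number from compound 2 to compound 4 (0.25 log units; that floor lies within the scatter) in the direction of a lower number. In this assay the estimate for compound 4 is 28000 nM with an expected range from 10000 nM to 50000 nM and this remains an expectation only.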

Compound 4, half-maximal inhibitory concentration: 36000 nM
Compound 4: the middle estimate sits 1.3-fold (0.11 log units) below what was measured; measured number inside the range.
By their numbers in this assay, from the lowest: compounds 3, 4 and 1 (each within the scatter of the next). At a limit, above all of these: compound 2.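

In this assay, (3-nitrophenyl)carbonyl in place of benzyl on this oxygen on a saturated carbon gives an at least 1.3-fold lower number from compound 2 to compound 4 (0.14 log units; that floor lies within the scatter). This is the first single change shown at this position, and it shows that compound 4, with the larger group, gives a real number, although the step cannot by itself establish a gain in potency. The step can only be stated as a floor, because compound 2 stands at a limit and not at a measured number: the limit of > 50000 nM in this assay, at which 1 of the 4 values shown sits.

Compound 4 brings in the carbonyl and the nitro group together, so the compounds shown cannot tell whether either one alone accounts for the number it gives, or whether the true step from the limit is small or large. An amine or a carboxylic acid in place of the nitro group, or a longer chain in place of the whole (3-nitrophenyl)carbonyl on the same oxygen, would test how much this position depends on the group attached there.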